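From a Hexynyl Chain to a Hydroxy Group

The source may hold more compounds than are shown below. What is called first, only, known or untested is meant among the compounds shown, and "the series" means these compounds.

In an ADME assay on L1210/0 cells (Mus musculus) for cytotoxicity, with a stated time of 48 h (a lower number here means a stronger inhibitor, a higher number a weaker inhibitor), compound 3 `CCCCC#Cc1cn([C@H]2C[C@H](O)[C@@H](CO)O2)c(=O)[nH]c1=O` gives > 200000 nM as its result, which is a limit and not a number. On the same test, compound 1 `N#CSc1cn([C@H]2C[C@H](O)[C@@H](CO)O2)c(=O)[nH]c1=O` gives 78900 nM and compound 2 `C=C(Cl)c1cn([C@H]2C[C@H](O)[C@@H](CO)O2)c(=O)[nH]c1=O` gives 1660 nM as measured numbers.

Compound 4 `O=c1[nH]c(=O)n([C@H]2C[C@H](O)[C@@H](CO)O2)cc1O` has hydroxy in place of hex-1-yn-1-yl on an aromatic carbon. Two measured steps end at compound 3, and both show that hex-1-yn-1-yl goes with a higher number than the group it replaces: an at least 2.5-fold higher number from compound 1 to compound 3 (0.40 log units; beyond the scatter) and an at least 120-fold higher number from compound 2 to compound 3 (2.08 log units; beyond the scatter) are the sizes on record. The step of a 48-fold lower number from compound 1 to compound 2 (1.68 log units; beyond the scatter) also shows that a swap on this same carbon can move the number a long way. Among the compounds with values here, no measured compound carries hydroxy, so the size of the change stays uncertain, but a lower number is expected.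

The step expected in this assay is an at least 5.0-fold lower number from compound 3 to compound 4 (0.69 log units; beyond the scatter) on this estimate. Compound 4 is estimated at 40000 nM with a range of 5000 nM to 200000 nM in this test.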

Compound 4, half-maximal inhibitory concentration: > 200000 nM
Compound 4: no number, only a limit (the forecaster's own chance of this, stated with the estimate: 25%); middle value at least 5.0-fold (0.69 log units) from the limit.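

In this assay compound 4 gives > 200000 nM, which is a limit and not a number, so hydroxy on this aromatic carbon yields no measurable result within the range of the test. Putting hydroxy in place of either group that gave a measured number raises the result, with an at least 120-fold higher number from compound 2 to compound 4 (2.08 log units; beyond the scatter) and an at least 2.5-fold higher number from compound 1 to compound 4 (0.40 log units; beyond the scatter), so removing the hexynyl chain does not by itself bring the number down. Until now only one group sat at this limit, and two very different groups now share it: the limit of > 200000 nM in this assay, at which 2 of the 4 values shown sit.

On these data alone, the results for compound 3 and compound 4 are both limits, so the step between them cannot be read, and which of these two groups goes with the higher number stays open. Also open, as far as these compounds go, is how an amine, a methoxy group or a shorter alkyne such as ethynyl on this carbon would compare with the 1-chloroethenyl group of compound 2.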